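The source may report more compounds than this note shows. Statements on the series, on what has been measured and on what is new or still open speak of the compounds shown alone.

Compound 1 `Cc1ccc2oc(-c3ccc(Cl)cc3)cc(=O)c2c1`: "not determined" (no result reported)
Compound 2 `CCN(CC)Cc1cccc2c(=O)cc(-c3ccc([N+](=O)[O-])cc3)oc12`: "not determined" (no result reported)
Compound 3 `CCN(CC)Cc1cc(Cl)cc2c(=O)cc(-c3ccc([N+](=O)[O-])cc3)oc12`: 2990 nM

Among the measured compounds shown here, in a functional assay on SMMC-7721 cells (Homo sapiens) for cytotoxicity, read by MTT assay, with a stated time of 48 h (on this read-out higher numbers stand for weaker inhibition and lower numbers for stronger inhibition), compound 3 gives 2990 nM, the only number available, since neither compound 1 nor compound 2 has a reported result. Its standing therefore cannot be judged against any other measured compound. Compound 4 `O=c1cc(-c2ccc([N+](=O)[O-])cc2)oc2c(CN3CCCCC3)cc(Cl)cc12` differs from compound 3 as follows: piperidin-1-yl in place of diethylamino on a saturated chain carbon bound to an aromatic carbon. For the measured compounds named here, no measured pair shows what this exchange does in this assay, so the expectation rests on compound 3 alone, at 2990 nM. No step beyond the usual scatter is expected, and neither direction is favoured. The estimated change is a 1.1-fold lower number from compound 3 to compound 4 (0.04 log units; within the scatter). Compound 4 is expected at 2700 nM, with an estimated range of 1000 nM to 7000 nM.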

Compound 4, half-maximal inhibitory concentration: 1090 nM
For compound 4 the middle estimate is 2.5-fold (0.39 log units) above the measured one, and the stated range covers the measured number.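

In this assay, piperidin-1-yl in place of diethylamino on a saturated chain carbon bound to an aromatic carbon gives a 2.7-fold lower number from compound 3 to compound 4 (0.44 log units; beyond the scatter), a modest step beyond the scatter. Among the compounds shown here, this is the first matched pair, and it shows that the number responds to which amine stands at this place. Nothing measured here explains the step. The compounds shown leave open how a morpholin-4-yl or pyrrolidin-1-yl group would read at this place. They also leave open whether the step holds on a core without the chloro group.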